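Amide chain lengthening in an aryl sulfonate series

The compounds below may be only part of what the source reports. "The series", "measured", "known", "first", "only" and "open" are said of these compounds alone.

Measured so far:
compound 1 `CC(=O)Nc1cccc(S(=O)(=O)Oc2ccccc2C(C)C)c1`, in a functional assay on HT-29 cells (Homo sapiens) for antiproliferative activity, read by sulforhodamine B assay, with a stated time of 48 h (a higher number here means a weaker inhibitor, a lower number a stronger inhibitor), compound 1 gives 27000 nM
compound 2 `CCC(=O)Nc1cccc(S(=O)(=O)Oc2ccccc2C(C)C)c1`, in this assay compound 2 gives 22000 nM

For the measured compounds named here, compound 2 holds the lower of the two numbers, and the one step measured so far is a 1.2-fold lower number from compound 1 to compound 2 (0.09 log units; within the scatter). Compound 3 `CCCC(=O)Nc1cccc(S(=O)(=O)Oc2ccccc2C(C)C)c1` carries the next change of the same kind: methyl in place of hydrogen on a saturated chain carbon, two bonds along the chain from a carbonyl carbon. Going by the values given here, only that single step bears on it, and it lay within the scatter, so the expectation in this assay is a small lowering at most, nothing beyond the scatter. Compound 3 is therefore estimated at 18000 nM, with a range from 9000 nM to 36000 nM. The expected step is a 1.2-fold lower number from compound 2 to compound 3 (0.09 log units; within the scatter).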

Compound 3, half-maximal inhibitory concentration: 13000 nM
The estimate for compound 3 lay 1.4-fold (0.14 log units) above the measured number, within the range that was stated.
By their numbers in this assay, from the lowest: compounds 3, 2 and 1 (each within the scatter of the next, the first and the last beyond it).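

In this assay, methyl in place of hydrogen two bonds along the chain from a carbonyl carbon gives a 1.7-fold lower number from compound 2 to compound 3 (0.23 log units; within the scatter), so this single change remains unresolved. Ethyl in place of hydrogen on the saturated chain carbon bound to a carbonyl carbon gives a 2.1-fold lower number from compound 1 to compound 3 (0.32 log units; beyond the scatter), a modest step and the first in this series to pass the scatter. No evidence bearing on the cause of this step is available. On these data alone, whether a longer chain such as pentanoyl lowers the number further remains open, as does the effect of an amine or carboxylic acid at the chain end.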